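A few compounds are considered here, and "the series" means these few. Any claim that something is new, unique, unknown or untested is made for them only; others in the source may bear on it.

Measured so far in a functional assay on a cell-free system (plasma) for agonist activity at thromboxane A2 receptor (Homo sapiens); a lower number here means a stronger inhibitor, a higher number a weaker inhibitor: compound 1 `O=C(O)CCC/C=C1/C[C@H]2C[C@@H](O)[C@H](/C=N/NC(=O)Nc3ccc([N+](=O)[O-])cc3)[C@H]2C1` gives 50 nM; compound 2 `O=C(O)CCC/C=C1\C[C@H]2C[C@@H](O)[C@H](/C=N/NC(=O)Nc3ccc([N+](=O)[O-])cc3)[C@H]2C1` gives 60 nM; compound 3 `O=C(O)COC/C=C1/C[C@H]2C[C@@H](O)[C@H](/C=N/NC(=O)Nc3ccc([N+](=O)[O-])cc3)[C@H]2C1` gives 20 nM.

Compound 1 holds the second highest of these three numbers. Compound 2 is nearest, with a 1.2-fold higher number from compound 1 to compound 2 (0.08 log units; within the scatter), a difference tied to the fact that compounds 1 and 2 differ only in the configuration as drawn. Compound 3 is furthest, with a 2.5-fold lower number from compound 1 to compound 3 (0.40 log units; beyond the scatter).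

Compound 4 `O=C(O)CCC/C=C1/C[C@H]2CC[C@H](/C=N/NC(=O)Nc3ccc([N+](=O)[O-])cc3)[C@H]2C1` differs from compound 1 by hydrogen in place of hydroxy on a saturated ring carbon. Neither measured step touches this place: the step to compound 2 alters only the drawn configuration, and the step to compound 3 alters the chain. Within the data shown here, no measured step therefore bears on this change, and the removed hydroxy counts one hydrogen-bond donor and one acceptor. Compound 4 is expected to give 120 nM, with a range of 35 nM to 400 nM. As an estimate this means a 2.4-fold higher number from compound 1 to compound 4 (0.38 log units; beyond the scatter).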

Compound 4, half-maximal inhibitory concentration: 580 nM
Beside the measured number, compound 4's estimate is 4.8-fold (0.68 log units) below it, outside the stated range (above it).
By their numbers in this assay, from the lowest: compound 3; then compounds 1 and 2 (each within the scatter of the next); then compound 4.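

In this assay, this saturated ring carbon proves sensitive to the change from hydroxy to hydrogen: a 12-fold higher number from compound 1 to compound 4 (1.06 log units; beyond the scatter). This step is larger than the one seen on the chain, a 2.5-fold lower number from compound 1 to compound 3 (0.40 log units; beyond the scatter), and the step in drawn configuration at the double bond, a 1.2-fold higher number from compound 1 to compound 2 (0.08 log units; within the scatter), so the hydroxy matters more here than either earlier change. Nothing measured here bears on why the number rises at this position.

The compounds shown leave open whether a methoxy or an amine on this ring carbon would hold the number of compound 1. They also leave open whether losing the hydroxy would cost as much with the carboxymethoxy chain of compound 3.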